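The source may hold more compounds than are shown below. What is called first, only, known or untested is meant among the compounds shown, and "the series" means these compounds.

Measured compounds:
- compound 1, `CCn1nc(C(=O)N[C@H]2COc3ccccc3N(C)C2=S)nc1Cc1ccccc1`: 17 nM
- compound 2, `CCCCn1nc(C(=O)N[C@H]2COc3ccccc3N(C)C2=S)nc1Cc1ccccc1`: 510 nM

In a functional assay on HT-29 cells (Homo sapiens) for inhibition, read by luminescence and CellTiter-Glo, with a stated time of 24 h (on this read-out lower numbers stand for an effect already at smaller amounts and higher numbers for an effect only at larger amounts of compound), compound 1 gives the lower of the two numbers, and compound 2 the higher, the step being a 30-fold higher number from compound 1 to compound 2 (1.48 log units; beyond the scatter). This step is the only one that bears on the unmeasured compound 3, `CC(C)Cn1nc(C(=O)N[C@H]2COc3ccccc3N(C)C2=S)nc1Cc1ccccc1`, which differs from compound 1 by isopropyl in place of methyl on a saturated chain carbon bound to an aromatic nitrogen; the same difference, cut one bond further out, reads ethyl to isobutyl. Compound 3 therefore carries the same count of carbon atoms on the aromatic nitrogen as compound 2 does, but arranged as a branched rather than a straight chain. The measured step from compound 1 to compound 2 shows that adding two carbons to this chain raised the number well beyond the scatter. A branched chain of the same size has not been measured, so the size of its effect is uncertain, but a rise in the same direction is the most reasonable expectation. The estimate for compound 3 is 200 nM, within 50 nM to 800 nM, which means an expected step of a 12-fold higher number from compound 1 to compound 3 (1.07 log units; beyond the scatter).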

Compound 3, half-maximal effective concentration: 1230 nM
The estimate for compound 3 lay 6.2-fold (0.79 log units) below the measured number, outside the stated range (above it).
By their numbers in this assay, from the lowest: compound 1; then compound 2; then compound 3.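

In this assay, the new result shows that this place responds to the shape of the chain as well as to its length: replacing the straight chain with the branched one gives a 2.4-fold higher number from compound 2 to compound 3 (0.38 log units; beyond the scatter), a modest change but one beyond the scatter. Isopropyl in place of methyl at the same place gives a 72-fold higher number from compound 1 to compound 3 (1.86 log units; beyond the scatter), so with both larger chains the number lies far above that of compound 1, and the branched chain moves it furthest of the changes seen so far. No measurement available here accounts for either rise, or for the gap between the branched and straight chains.

The compounds shown leave open whether the number would fall further with a shorter group in this place, such as a single methyl, or whether ethyl already marks the low end. They also leave open how a chain carrying an amine or a hydroxyl group, or a small ring such as cyclopropyl, would behave here.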